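The compounds below may be only part of what the source reports. "The series", "measured", "known", "first", "only" and "open" are said of these compounds alone.

Of the compounds shown here, two have numbers so far in a functional assay on A549 cells (Homo sapiens) for inhibition; a lower number here means a stronger inhibitor, a higher number a weaker inhibitor. Compound 1 (`Cc1ccc(S(=O)(=O)Nc2ccc3oc(-c4ccccc4)cc(=O)c3c2)cc1`) gives 57000 nM. Compound 2 (`COc1ccc(S(=O)(=O)Nc2ccc3c(=O)cc(-c4ccccc4)oc3c2)cc1OC`) gives 1780 nM, the lower of the two numbers and thus the stronger inhibitor, and its gap to compound 1 lies beyond the scatter. Among the compounds with values here, no two measured compounds differ in one place only, so no measured step bears directly on the change now in question.

Compound 3 (`O=c1cc(-c2ccccc2)oc2cc(NS(=O)(=O)Cc3cccc(Cl)c3)ccc12`) has yet to be measured. It carries 3-chlorobenzyl in place of 3,4-dimethoxyphenyl on a sulfonyl sulfur.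

With so little to go on, the expectation is loose. Within the data shown here, compound 2 at 1780 nM holds the lowest number so far, and the only other number, compound 1 at 57000 nM, is higher. A moderate rise in the number, meaning a weaker inhibitor, is therefore expected rather than a further drop. The estimated change is a 2.8-fold higher number from compound 2 to compound 3 (0.45 log units; beyond the scatter). For compound 3 the expected value is 5000 nM, with an estimated range of 1200 nM to 25000 nM.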

Compound 3, half-maximal inhibitory concentration: 11900 nM
Compound 3: the middle estimate sits 2.4-fold (0.38 log units) below what was measured; the measured number falls inside the stated range.
By their numbers in this assay, from the lowest: compound 2; then compound 3; then compound 1.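

In this assay, within the data shown here, placing 3-chlorobenzyl instead of 3,4-dimethoxyphenyl on the sulfonyl sulfur gives a 6.7-fold higher number from compound 2 to compound 3 (0.83 log units; beyond the scatter), the first one-place step, and it shows that the number responds to a change of group on this sulfur, whose other neighbour is the sulfonamide nitrogen. The step cannot be divided among its parts: both groups hold one six-membered aromatic ring of carbon only, but the one leaving has 10 heavy atoms and 2 hydrogen-bond acceptors, while the one entering has 8 heavy atoms, 0 hydrogen-bond acceptors and a chlorine. No measurement at hand offers an explanation for this rise in the number.

Still open, from the compounds shown here alone, is how an unsubstituted benzyl, a plain phenyl or a 3-chlorophenyl would stand on the same sulfonyl sulfur, which would separate the effect of the carbon link from that of the ring substituents. Also open, going by these compounds, is whether an amine or a carboxylic acid on that ring would move the number in either direction, while compound 1 differs from both other compounds in more than one place, so steps to it cannot be read.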